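From Amino to Methoxy on the Shared Core

The source may report more compounds than this note shows. Statements on the series, on what has been measured and on what is new or still open speak of the compounds shown alone.

Compound 1 `CC(=O)OC(C)n1cnc2c(Cl)nc(I)nc21` gives 14100 nM in a functional assay on WI-38 cells (Homo sapiens) for inhibition; a higher number here means a weaker inhibitor, a lower number a stronger inhibitor.
Compound 2 `CC(O)n1cnc2c(N)nc(I)nc21` gives only the limit > 500000 nM in this assay.
Compound 3 `Nc1nc(I)nc2c1ncn2OCCO` gives only the limit > 500000 nM in this assay.

Compound 3 therefore stands at the limit of this assay, the point described by the limit of > 500000 nM in this assay, at which 2 of the 3 values shown sit. Within the data shown here, the one step measured between neighbours, a step that the two limits leave unreadable from compound 2 to compound 3, cannot be read because both ends are limits, so it gives no sense of size or direction. Among the measured compounds shown here, compound 1 is the only compound with a number, and it differs from compound 3 in more than one place, so it shows no single change either.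

Compound 4 `COc1nc(I)nc2c1ncn2OCCO` differs from compound 3 by methoxy in place of amino on an aromatic carbon. For the measured compounds named here, no measured step exchanges an amino for a methoxy group, so nothing measured bears on this change directly. Going by the values given here, the two closest compounds both sit at the limit, and that is the only guide.

Compound 4 is therefore expected to remain near the limit, estimated at 400000 nM with a range from 40000 nM to 1000000 nM. The step this estimate means, an at least 1.2-fold lower number from compound 3 to compound 4 (0.09 log units; that floor lies within the scatter), is expected to be no more than a move toward a readable number, most likely none beyond the scatter.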

Compound 4, half-maximal inhibitory concentration: > 500000 nM
Compound 4: only a limit was reported; the forecaster's own chance of this, stated with the estimate: 70%; at least 1.2-fold (0.09 log units) between middle value and limit.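

Compound 3 and compound 4 both give a limit rather than a number in this assay, so the step between them cannot be read: the limit of > 500000 nM in this assay, at which 3 of the 4 values shown sit.

The compounds shown leave open how far methoxy in place of amino on an aromatic carbon shifts inhibition, in either direction.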